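A few compounds are considered here, and "the series" means these few. Any claim that something is new, unique, unknown or untested is made for them only; others in the source may bear on it.

Compound 1 `CNC(=O)c1cc(Oc2ccc(NC(=O)c3nn(-c4ccc(Br)cc4F)c(=O)cc3C)cc2F)ccn1` and compound 2 `Cc1cc(=O)n(-c2ccc(Br)cc2F)nc1C(=O)Nc1ccc(Oc2ncnc3ccsc23)cc1` share the same core and differ only in the aryl ether attached to the amide. In a functional assay on MCF7 cells (Homo sapiens) for cytotoxicity, read by MTT assay, with a stated time of 72 h (on this read-out higher numbers stand for weaker inhibition and lower numbers for stronger inhibition), compound 1 gives 9360 nM. In this assay compound 2 gives 9360 nM, level with compound 1 at the digits shown, so the two lie within the scatter of each other and nothing can be said about an order between them.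

Compound 3 `Cc1cc(=O)n(-c2ccc(F)cc2)nc1C(=O)Nc1ccc(Oc2ncnc3ccsc23)cc1` is compound 2 with a change at the aromatic nitrogen of the core: 4-fluorophenyl in place of 4-bromo-2-fluorophenyl on an aromatic nitrogen. Going by the values given here, no pair of measured compounds differs by this change alone, so there is no measured step to lean on. The change is expected to bring no step beyond the scatter, and the step of a 1.2-fold higher number from compound 2 to compound 3 (0.07 log units; within the scatter) is the estimate that follows. Compound 3 is therefore expected to give 11000 nM in this assay, within a range from 4000 nM to 35000 nM.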

Compound 3, half-maximal inhibitory concentration: 4400 nM
For compound 3 the middle estimate is 2.5-fold (0.40 log units) above the measured one; low and high end bracket the measured number.
By their numbers in this assay, from the lowest: compound 3; then compounds 1 and 2 (each within the scatter of the next).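

On the aromatic nitrogen of the core, the aryl group is not a silent position. In this assay, 4-fluorophenyl in place of 4-bromo-2-fluorophenyl gives a modest step beyond the scatter (a 2.1-fold lower number from compound 2 to compound 3 (0.33 log units; beyond the scatter)), towards stronger inhibition. Compound 1 and compound 2 differ only in the aryl ether and stand level, so among the compounds shown, only this change at the nitrogen moves the number, and nothing at hand accounts for the step.

The compounds shown do not separate the part played by the bromine from that of the fluorine pattern, which a phenyl carrying only bromine or a plain phenyl on the same nitrogen would address. They also leave open whether the same step holds with the aryl ether of compound 1 in place.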